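Longer chain, bromine in place of chlorine

The source may hold more compounds than are shown below. What is called first, only, known or untested is meant among the compounds shown, and "the series" means these compounds.

Compound 1 `O=S(=O)(NCCCNCc1ccccc1Cl)c1cc(C(F)(F)F)cc(C(F)(F)F)c1`: 15000 nM
Compound 2 `CC(C)(C)c1ccc(CNCCCNS(=O)(=O)c2cc(C(F)(F)F)cc(C(F)(F)F)c2)cc1`: 2500 nM

Both compounds were tested in a functional assay on BE(2)-C cells (Homo sapiens) for inhibition, read by MTT assay, with a stated time of 72 h; on this read-out lower numbers stand for stronger inhibition of growth and higher numbers for weaker inhibition of growth. On these two numbers compound 1 stands highest, so it is the weaker of the pair. Going by the values given here, the one measured step, a 6.0-fold lower number from compound 1 to compound 2 (0.78 log units; beyond the scatter), came from exchanging the ring substituent on the benzyl arm while keeping the chain length. Compound 3 `O=S(=O)(NCCCCNCc1ccc(Br)cc1)c1cc(C(F)(F)F)cc(C(F)(F)F)c1` is not yet measured; it differs from compound 1 by ((4-bromobenzyl)amino)methyl in place of (2-chlorobenzyl)amino on a saturated chain carbon, three bonds along the chain from a sulfonamide nitrogen. Two things change at once: the ring substituent moves from a 2-chloro to a 4-bromo pattern, and the chain gains one carbon. Among the compounds with values here, the step to compound 2 shows that changing the substituent pattern on this ring can lower the number well beyond the scatter, but no measured pair speaks to the longer chain. A modest drop is therefore expected, a 3.0-fold lower number from compound 1 to compound 3 (0.48 log units; beyond the scatter), giving compound 3 an estimated 5000 nM, within 1500 nM to 15000 nM.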

Compound 3, concentration for 50% growth inhibition: 2200 nM
Estimate against measurement, compound 3: 2.3-fold (0.36 log units) above; the measured number falls inside the stated range.
By their numbers in this assay, from the lowest: compounds 3 and 2 (each within the scatter of the next); then compound 1.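

In this assay, placing ((4-bromobenzyl)amino)methyl where compound 1 carries (2-chlorobenzyl)amino gives a 6.8-fold lower number from compound 1 to compound 3 (0.83 log units; beyond the scatter). Going by these compounds alone, this is the first measured change at this position that also lengthens the chain, and the number still falls beyond the scatter, as it did in a 6.0-fold lower number from compound 1 to compound 2 (0.78 log units; beyond the scatter), where the chain stayed the same. Nothing measured here explains why the number falls, and no outside data bear on this step.

Because the ring substituent and the chain length change together in compound 3, the compounds shown cannot say how much of the step belongs to the bromine, its place on the ring, or the longer chain. Going by these compounds, a 4-bromobenzyl group on the shorter chain of compound 1, or a 2-chlorobenzyl group on the longer chain of compound 3, would separate these, while a still longer chain remains unexplored here.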